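Replacing tert-butyl on a carbonyl carbon

This account rests on a few compounds, and the source may have more. Where it says the series, first, only, none or still open, it means among the compounds named here.

In a physicochemical assay for solubility (a lower number here means a less soluble compound, a higher number a more soluble compound), compound 1 `O=C1CC[C@@H](C(=O)N2CCC(NS(=O)(=O)c3cc(S(=O)(=O)c4ccccc4)ccc3C(F)(F)F)CC2)N1` gives 100000 nM and compound 2 `CC(C)(C)C(=O)N1CCC[C@H]1C(=O)N1CCC(NS(=O)(=O)c2cc(S(=O)(=O)c3ccccc3)ccc2C(F)(F)F)CC1` gives 50000 nM. Within the data shown here, these are the only two numbers so far, and they lie within the usual scatter of each other, so compound 2 cannot be placed clearly apart from compound 1.

Compound 3 `CN(C)c1ccc(C(=O)N2CCC[C@H]2C(=O)N2CCC(NS(=O)(=O)c3cc(S(=O)(=O)c4ccccc4)ccc3C(F)(F)F)CC2)cc1` has not yet been measured. It differs from compound 2 in one place, with 4-(dimethylamino)phenyl in place of tert-butyl on a carbonyl carbon.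

Among the measured compounds shown here, only one measured step bears on this change: a 2.0-fold lower number from compound 1 to compound 2 (0.30 log units; within the scatter). That step brought in the (tert-butyl)carbonyl group and stayed within the scatter. For the measured compounds named here, it is a weak guide, as no measured compound carries the 4-(dimethylamino)phenyl group. With a larger group entering, the expected step in this assay is a modest one towards a lower number: a 2.5-fold lower number from compound 2 to compound 3 (0.40 log units; beyond the scatter). This step may well turn out to be no larger than the scatter. For compound 3 the estimated value is 20000 nM, within an expected range of 5000 nM to 60000 nM.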

Compound 3, solubility: 100000 nM
For compound 3 the middle estimate is 5.0-fold (0.70 log units) below the measured one, outside the stated range (above it).
By their numbers in this assay, from the lowest: compounds 2, 1 and 3 (each within the scatter of the next).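

In this assay, putting 4-(dimethylamino)phenyl in place of tert-butyl on the carbonyl carbon gives a 2.0-fold higher number from compound 2 to compound 3 (0.30 log units; within the scatter), so the two numbers cannot be told apart. Among these compounds, this is the first measured change at this position, on a carbonyl carbon whose other neighbour is an amide-type nitrogen in a ring, and it shows that a compact, ring-free tert-butyl and a larger group with a six-membered aromatic ring and a hydrogen-bond acceptor can sit here without a step beyond the scatter. No measurement shown here accounts for this result.

A single pair cannot show whether the aromatic ring and the dimethylamino group each leave the number unmoved or whether their contributions merely offset each other, and a plain phenyl on the same carbonyl carbon would help to separate the two. Going by these compounds, it also remains open whether any group at this position can move the number beyond the scatter, for instance a carboxylic acid, a primary amine or a longer alkyl chain.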